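A few compounds are considered here, and "the series" means these few. Any claim that something is new, unique, unknown or untested is made for them only; others in the source may bear on it.

Measured so far in a functional assay on HCT-15 cells (Homo sapiens) for cytotoxicity, read by ELISA, with a stated time of 4 days; on this read-out lower numbers stand for stronger inhibition and higher numbers for weaker inhibition:
- compound 1 `Cc1ccccc1-c1cc(-c2ccoc2)cc(-c2ccc(Cl)s2)n1` gives 990 nM
- compound 2 `Clc1ccc(-c2cc(-c3ccoc3)cc(-c3ccc(Cl)s3)n2)cc1` gives 640 nM

For the measured compounds named here, compound 2 cannot be ranked against compound 1, for the only measured step is a 1.5-fold lower number from compound 1 to compound 2 (0.19 log units; within the scatter) and it leaves the two together. Compound 3 `Clc1ccc(-c2cc(-c3ccoc3)cc(-c3ccccn3)n2)s1` carries pyridin-2-yl in place of 4-chlorophenyl on an aromatic carbon, next to the ring nitrogen (pyridin-2-yl in place of 4-chlorophenyl on an aromatic carbon). The measured step changed that same place, but pyridin-2-yl itself has no measurement there, so no step beyond the scatter is expected in this assay. The expected change is a 1.3-fold higher number from compound 2 to compound 3 (0.10 log units; within the scatter) by this estimate. Compound 3 is estimated at 800 nM (250 nM to 2600 nM).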

Compound 3, half-maximal inhibitory concentration: 1270 nM
Compound 3: the middle estimate sits 1.6-fold (0.20 log units) below what was measured; measured number inside the range.
By their numbers in this assay, from the lowest: compounds 2, 1 and 3 (each within the scatter of the next).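

With pyridin-2-yl at this place, this assay gives a 2.0-fold higher number from compound 2 to compound 3 (0.30 log units; within the scatter) and a 1.3-fold higher number from compound 1 to compound 3 (0.11 log units; within the scatter). The ring nitrogen and its hydrogen-bond acceptor therefore bring no step beyond the scatter, and 4-chlorophenyl, 2-methylphenyl and pyridin-2-yl cannot be told apart here. No evidence is available that bears on this result. On these data alone, it remains open whether a group other than a six-membered aromatic ring at this place, such as an amine or a carboxylic acid, would move the number beyond the scatter. As far as these compounds go, the contribution of the 5-chlorothiophen-2-yl and furan-3-yl groups also remains open.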